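This account rests on a few compounds, and the source may have more. Where it says the series, first, only, none or still open, it means among the compounds named here.

Three related compounds have been tested in a functional assay on DLD-1 cells (Homo sapiens) for cytotoxicity, read by MTT assay, with a stated time of 72 h; a lower number here means a stronger inhibitor, a higher number a weaker inhibitor. Compound 1 `Cc1c(/N=C/c2ccc(N(C)C)cc2)c(=O)n(-c2ccccc2)n1C` gives 871000000 nM in this assay. Compound 2 `COc1ccc(/C=N/c2c(C)n(C)n(-c3ccccc3)c2=O)cc1` gives 977000000 nM, and compound 3 `COc1ccc(/C=N/c2c(C)n(C)n(-c3ccccc3)c2=O)cc1OC` gives 676000000 nM. Compound 2 has the highest number of the three, but its distance to each of the others is small: the step of a 1.1-fold higher number from compound 1 to compound 2 (0.05 log units; within the scatter) and the step of a 1.4-fold lower number from compound 2 to compound 3 (0.16 log units; within the scatter) both lie within the scatter of repeated measurements, so the three compounds cannot really be told apart in this assay.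

Compound 4 `COc1ccccc1/C=N/c1c(C)n(C)n(-c2ccccc2)c1=O` has not yet been measured. It differs from compound 2 in one place: 2-methoxyphenyl in place of 4-methoxyphenyl on a carbon with a double bond to nitrogen. The two measured steps both alter the groups carried by the same aromatic ring and move the number hardly at all; neither of them, however, relocates a group within that ring, so the present change is not directly covered by any measured pair. With no sign so far of a sizeable effect from any change on this ring, compound 4 is expected to land close to compound 2, a step of a 1.0-fold lower number from compound 2 to compound 4 (0.01 log units; within the scatter). The estimate for compound 4 in this assay is 950000000 nM, with a range from 450000000 nM to 2000000000 nM.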

Compound 4, half-maximal inhibitory concentration: 933000000 nM
Estimate against measurement, compound 4: 1.0-fold (0.01 log units) above, and the stated range covers the measured number.
By their numbers in this assay, from the lowest: compounds 3, 1, 4 and 2 (each within the scatter of the next).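

In this assay, 2-methoxyphenyl in place of 4-methoxyphenyl on a carbon with a double bond to nitrogen gives a 1.0-fold lower number from compound 2 to compound 4 (0.02 log units; within the scatter). The earlier steps shown here changed which groups the aromatic ring carried, whereas this one keeps the same atoms and only joins them differently, so it adds a different kind of change, and the result again lies within the scatter. Nothing measured here offers an explanation for this result.

The groups shown on this ring are only dimethylamino and methoxy, so it remains open whether a quite different group, such as a carboxylic acid, a primary amine or a longer alkoxy chain, would give a number that can be told apart from these. The rest of the molecule is the same in all four compounds, which leaves open how the number would respond if the phenyl group on the shared core gave way to, for example, a benzyl group or a simple alkyl chain.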